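The source may report more compounds than this note shows. Statements on the series, on what has been measured and on what is new or still open speak of the compounds shown alone.

Series notes on salicylanilide-type amides in a functional assay on NALM-6 cells (Homo sapiens) for cytotoxicity, read by luminescence and CellTiter-Glo, with a stated time of 3 days; on this read-out higher numbers stand for weaker inhibition and lower numbers for stronger inhibition.

Of the compounds shown here, three have numbers so far. Compound 1 `O=C(Nc1ccc(C(F)(F)F)cc1)c1cc(Br)ccc1O` gives 1090 nM in this assay. Compound 2 `O=C(Nc1ccc(Br)c(Cl)c1)c1cc(F)ccc1O` gives 1250 nM in this assay. Compound 3 `O=C(Nc1cc(C(F)(F)F)cc(C(F)(F)F)c1)c1cc(F)ccc1O` gives 620 nM in this assay. Compound 1 stands second highest of the three numbers; its nearest neighbour is compound 2, whose number lies within the scatter of compound 1, and the furthest is compound 3, whose lower number also lies within the scatter. Taken together, the three values do not separate from one another, so no order among them can be stated.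

Compound 4 `O=C(Nc1ccc(C(F)(F)F)cc1)c1cc(Cl)ccc1O` is not yet measured in this assay. It differs from compound 1 in one place: chloro in place of bromo on an aromatic carbon. The swap sits on the six-membered aromatic ring of carbon only, meta to a large group and para to the hydroxy group. For the measured compounds named here, no pair of measured compounds differs by this single change, so there is nothing in the numbers themselves to set its size.

A halogen-for-halogen exchange of this kind is expected to give, at most, a small step, and the working expectation is none beyond the scatter, with the number for compound 4 perhaps slightly higher than that of compound 1; the expected step is a 1.2-fold higher number from compound 1 to compound 4 (0.08 log units; within the scatter). Compound 4 is therefore estimated at 1300 nM, with a range from 600 nM to 2800 nM.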

Compound 4, half-maximal inhibitory concentration: 1210 nM
Compound 4: middle estimate off by 1.1-fold (0.03 log units), on the high side, and the stated range covers the measured number.
By their numbers in this assay, from the lowest: compounds 3, 1, 4 and 2 (each within the scatter of the next).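

For the compounds shown here, the step of a 1.1-fold higher number from compound 1 to compound 4 (0.05 log units; within the scatter) in this assay is the first comparison between compounds that differ in one place, and it lies within the scatter. On this aromatic carbon, para to a hydroxy group and meta to a large group, bromo and chloro therefore cannot be told apart in this read-out, at least with the rest of compound 1 held fixed. The earlier compounds differ from one another in more than one place and could not isolate this change, and nothing measured here bears on the reason for the result.

From the compounds shown here alone, it remains open whether a group that is not a halogen at this position, such as an amine, a carboxylic acid or a longer alkyl chain, would give a step beyond the scatter in this assay. Also open are whether the same exchange stays within the scatter when the trifluoromethyl group elsewhere in the core is replaced, and what happens when the hydroxy group, present in all compounds shown, is exchanged for a methoxy group.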